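Replacing Trifluoromethyl on the Carbonyl with an Oxadiazole Ring

This account rests on a few compounds, and the source may have more. Where it says the series, first, only, none or still open, it means among the compounds named here.

Of the compounds shown here, three sharing one core have been measured in a functional assay on isolated protein for inhibition of Glucose-dependent insulinotropic receptor (Rattus norvegicus), read by HTRF and cAMP accumulation; on this read-out higher numbers stand for an effect only at larger amounts of compound and lower numbers for an effect already at smaller amounts. Compound 1 `Cc1nc(S(C)(=O)=O)ccc1Oc1ncnc(OC2CCN(C(=O)O[C@H](C)C(F)(F)F)CC2)c1F` gives 110 nM, compound 2 `CCC1(OC(=O)N2CCC(Oc3ncnc(Oc4ccc(S(C)(=O)=O)nc4C)c3F)CC2)CC1` gives 333 nM, and compound 3 `Cc1nc(S(C)(=O)=O)ccc1Oc1ncnc(OC2CCN(C(=O)C(F)(F)F)CC2)c1F` gives 880 nM. Compound 3 stands highest of the three: the step of an 8.0-fold higher number from compound 1 to compound 3 (0.90 log units; beyond the scatter) and the step of a 2.6-fold higher number from compound 2 to compound 3 (0.42 log units; beyond the scatter) both lie beyond the scatter, and the step of a 3.0-fold higher number from compound 1 to compound 2 (0.48 log units; beyond the scatter) lies beyond it as well.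

Compound 4 `Cc1nc(S(C)(=O)=O)ccc1Oc1ncnc(OC2CCN(C(=O)c3nc(C(C)(C)F)no3)CC2)c1F` differs from compound 3 only on the carbonyl carbon: a group of 9 heavy atoms (5 carbon, 2 nitrogen, 1 oxygen, 1 fluorine; one five-membered aromatic ring with 3 hetero atoms) in place of a group of 4 heavy atoms (1 carbon, 3 fluorine; no ring), on a carbonyl carbon. The two measured steps that bear on this place, an 8.0-fold higher number from compound 1 to compound 3 (0.90 log units; beyond the scatter) and a 2.6-fold higher number from compound 2 to compound 3 (0.42 log units; beyond the scatter), both show the four-atom trifluoromethyl group giving the higher number, while the larger groups of compound 1 and compound 2 give the lower numbers. The entering nine-atom ring-bearing group is again larger than trifluoromethyl, so for compound 4 a lower number in this assay is expected, a step of about a 4.4-fold lower number from compound 3 to compound 4 (0.64 log units; beyond the scatter). Compound 4 is estimated at 200 nM, with a range from 50 nM to 800 nM.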

Compound 4, half-maximal effective concentration: 606 nM
Beside the measured number, compound 4's estimate is 3.0-fold (0.48 log units) below it; the range from low to high includes it.
By their numbers in this assay, from the lowest: compound 1; then compounds 2, 4 and 3 (each within the scatter of the next, the first and the last beyond it).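

Greater size alone does not set the number at this position: the group with the five-membered aromatic ring is larger than trifluoromethyl, yet in this assay the result is a 1.5-fold lower number from compound 3 to compound 4 (0.16 log units; within the scatter), which goes against the earlier link between larger groups and lower numbers. The same holds against the ring-containing group of compound 2, with a 1.8-fold higher number from compound 2 to compound 4 (0.26 log units; within the scatter), whereas a 5.5-fold higher number from compound 1 to compound 4 (0.74 log units; beyond the scatter) shows that the 1-(trifluoromethyl)ethoxy group of compound 1 still gives the lowest number of the four. Nothing measured here explains why these groups differ.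

Among these compounds, only one group with an aromatic ring on the carbonyl carbon appears here, and its own side chain is never varied. A plain phenyl ring or a methyl group on the same five-membered ring remains an open test of how far this result extends.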